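A trifluoromethyl variant of compound 2

The source may report more compounds than this note shows. Statements on the series, on what has been measured and on what is new or still open speak of the compounds shown alone.

Compound 2 `Cc1cc(-c2nc(-c3ccc4[nH]c(=O)oc4c3)cs2)ccc1F` in an assay on isolated protein for inhibition of protein phosphatase 1D (Homo sapiens), read by malachite green (a lower number here means a stronger inhibitor, a higher number a weaker inhibitor), gives < 20000 nM, which is a limit of the assay rather than a number. Compound 1 `O=c1[nH]c2ccc(-c3csc(-c4ccc(F)c(F)c4)n3)cc2o1` in this assay gives < 20000 nM, likewise a limit. The step that the two limits leave unreadable from compound 1 to compound 2 therefore cannot be read, and the limit of < 20000 nM in this assay, at which 2 of the 2 values shown sit, marks where both values sit. Compound 3 `O=c1[nH]c2ccc(-c3csc(-c4ccc(F)c(C(F)(F)F)c4)n3)cc2o1` differs from compound 2 by trifluoromethyl in place of methyl on an aromatic carbon. For the measured compounds named here, no measured step bears readably on this change, so no step beyond the scatter is expected in this assay in either direction, and a limit may again be reported. Compound 3 is estimated at 8000 nM, between 1500 nM and 20000 nM. The expected step is a step that the limit leaves unreadable from compound 2 to compound 3.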

Compound 3, half-maximal inhibitory concentration: < 20000 nM
Compound 3: a limit, no number; the forecaster's own chance of this, stated with the estimate: 60%; the middle value lies beyond the limit too.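

For the compounds shown here, compound 3 again gives only a limit in this assay, not a number, so no step among compound 1, compound 2 and compound 3 can be read: the limit of < 20000 nM in this assay, at which 3 of the 3 values shown sit. The compounds shown leave open whether fluoro, methyl or trifluoromethyl on this aromatic carbon makes any difference to inhibition.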